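Trading a methoxymethyl chain for a lactam ring

The compounds below may be only part of what the source reports. "The series", "measured", "known", "first", "only" and "open" are said of these compounds alone.

Compound 1, `CCN(CC)c1ccc(NC(=O)c2c(-c3c(Cl)cccc3Cl)noc2CCOC)cc1`: 110 nM
Compound 2, `CCN(CC)c1ccc(NC(=O)c2c(-c3c(Cl)cccc3Cl)noc2CCC2CCCO2)cc1`: 57 nM

Going by the values given here, in an in vitro assay on CHO-K cells with growth hormone secretagogue receptor type 1 (Homo sapiens) as the target (on this read-out lower numbers stand for stronger inhibition and higher numbers for weaker inhibition), compound 1 stands highest of the two numbers, and its only neighbour is compound 2 at 57 nM. Among the compounds with values here, the single measured step, a 1.9-fold lower number from compound 1 to compound 2 (0.29 log units; within the scatter), is a change on the same side chain and gives no shift that rises above the scatter. Compound 3, `CCN(CC)c1ccc(NC(=O)c2c(-c3c(Cl)cccc3Cl)noc2CN2CCCC2=O)cc1`, differs from compound 1 by 2-oxopyrrolidin-1-yl in place of methoxymethyl on a saturated chain carbon bound to an aromatic carbon. Within the data shown here, the step from compound 1 to compound 2 is the only guide, and it shows the chain end tolerating a ring without a clear gain; the change to compound 3 is larger, replacing 2-methoxyethyl with (2-oxopyrrolidin-1-yl)methyl, and no measured pair covers it. The step of a 1.4-fold higher number from compound 1 to compound 3 (0.13 log units; within the scatter) is therefore expected to stay within the scatter. Compound 3 is estimated at 150 nM, between 50 nM and 450 nM.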

Compound 3, half-maximal inhibitory concentration: 122 nM
Compound 3: middle estimate off by 1.2-fold (0.09 log units), on the high side; low and high end bracket the measured number.
By their numbers in this assay, from the lowest: compounds 2, 1 and 3 (each within the scatter of the next, the first and the last beyond it).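

In this assay, 2-oxopyrrolidin-1-yl is tolerated in place of methoxymethyl on a saturated chain carbon bound to an aromatic carbon: a 1.1-fold higher number from compound 1 to compound 3 (0.04 log units; within the scatter), so the two numbers cannot be told apart despite the added ring and the 6 heavy atoms against 3. Set against the oxolan-2-yl chain, the same position gives a 2.1-fold higher number from compound 2 to compound 3 (0.33 log units; beyond the scatter), a modest step and the first among these compounds to pass the scatter. Nothing measured here accounts for either step.

The compounds shown leave open how a plain pyrrolidin-1-yl ring without the carbonyl, or a carboxylic acid, would read on this carbon. They also leave open whether 2-oxopyrrolidin-1-yl carried on a longer chain would give a number closer to that of compound 2.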